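The compounds below may be only part of what the source reports. "The series", "measured", "known", "first", "only" and "open" are said of these compounds alone.

Compound 1 `O=C1/C(=C/c2ccccc2Cl)CCCc2ccccc21` is a ketone whose shared core carries a chloro-substituted aromatic ring. In a functional assay on P388 cells (Mus musculus) for inhibition (a lower number here means a stronger inhibitor, a higher number a weaker inhibitor), compound 1 gives 12700 nM. Compound 3 `COc1ccccc1/C=C1\CCCc2ccccc2C1=O` gives 18000 nM, and the step of a 1.4-fold higher number from compound 1 to compound 3 (0.15 log units; within the scatter) means that the two numbers shown cannot be told apart, so compound 1 stands level with compound 3 rather than apart from it. Compound 2 `O=C1/C(=C/c2ccccc2Br)Cc2ccccc21` gives only > 50000 nM in this assay, which is a limit of the assay and not a number. Compound 4 `O=C1/C(=C/c2ccc(Cl)cc2Cl)CCCc2ccccc21` differs from compound 1 by chloro in place of hydrogen on an aromatic carbon. Within the data shown here, no measured step adds a chloro group, and the one measured step is within the scatter, so no change beyond the scatter is expected. Compound 4 is therefore estimated at 10000 nM, between 4000 nM and 30000 nM, a step of a 1.3-fold lower number from compound 1 to compound 4 (0.10 log units; within the scatter).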

Compound 4, half-maximal inhibitory concentration: 14000 nM
Beside the measured number, compound 4's estimate is 1.4-fold (0.15 log units) below it; the range from low to high includes it.
By their numbers in this assay, from the lowest: compounds 1, 4 and 3 (each within the scatter of the next). At a limit, above all of these: compound 2.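

In this assay, chloro in place of hydrogen gives a 1.1-fold higher number from compound 1 to compound 4 (0.04 log units; within the scatter), so this aromatic carbon, para to a large group and meta to a chloro group, takes the added chloro with no change that can be told from the scatter. The earlier step replaced the existing chloro group and did not touch this carbon. Nothing shown here gives a cause for this result. From the compounds shown here alone, whether an amine or a carboxylic acid on this same carbon would shift the number remains open.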